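The source may report more compounds than this note shows. Statements on the series, on what has been measured and on what is new or still open speak of the compounds shown alone.

Measured compounds, each with its value in an assay on tissue (HeLa cells) for inhibition of Indoleamine 2,3-dioxygenase 1 (Homo sapiens), read by spectrophotometry; on this read-out higher numbers stand for weaker inhibition and lower numbers for stronger inhibition:

compound 1 `O/N=C(/NCc1cccc(Cl)c1)c1ccc2occc2c1`: 5800 nM
compound 2 `O/N=C(/NCc1cccs1)c1ccc2occc2c1`: 16200 nM
compound 3 `O/N=C(/NCc1ccco1)c1ccc2occc2c1`: only a limit of the assay, > 30000 nM

All three share the same core and differ only in the ring carried on a saturated chain carbon bound to an amine nitrogen. Compound 3 stands at the limit of the assay, so its exact number is not known; it sits at the limit of > 30000 nM in this assay, at which 1 of the 3 values shown sits. Among the measured steps, two lead into compound 3: an at least 5.1-fold higher number from compound 1 to compound 3 (0.71 log units; beyond the scatter) and an at least 1.8-fold higher number from compound 2 to compound 3 (0.26 log units; that floor lies within the scatter). The first is clearly beyond the scatter, the second reaches only a floor that lies within it. The third step, a 2.8-fold higher number from compound 1 to compound 2 (0.45 log units; beyond the scatter), shows that the 3-chlorophenyl ring gives the strongest inhibition shown here.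

Compound 4 `O/N=C(/NCC1CC1)c1ccc2occc2c1` is not yet measured. Its change from compound 3 is cyclopropyl in place of furan-2-yl on a saturated chain carbon bound to an amine nitrogen: the aromatic five-membered ring leaves and a small saturated ring enters. For the measured compounds named here, no measured step covers a non-aromatic ring at this place, so the expectation rests on the trend that the furan already sits at the limit. The step is expected to be a step that the limit leaves unreadable from compound 3 to compound 4, that is, no gain in this assay and most likely another limit. Compound 4 is therefore estimated at 40000 nM, with a range from 15000 nM to 120000 nM.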

Compound 4, half-maximal inhibitory concentration: > 30000 nM
Compound 4: only a limit was reported; the forecaster's own chance of this, stated with the estimate: 70%; the middle value lies beyond the limit too.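

Compound 4 gives only a limit of the assay in this assay, and a non-aromatic ring now joins the furan-2-yl ring there: the limit of > 30000 nM in this assay, at which 2 of the 4 values shown sit. Both of these values are limits, so the step from compound 3 to compound 4 cannot be read. Cyclopropyl in place of 3-chlorophenyl gives an at least 5.1-fold higher number from compound 1 to compound 4 (0.71 log units; beyond the scatter), so this small saturated ring loses inhibition clearly, while cyclopropyl in place of thiophen-2-yl gives an at least 1.8-fold higher number from compound 2 to compound 4 (0.26 log units; that floor lies within the scatter), which does not separate the two.

Still open, on these data alone, is whether a plain phenyl ring without the chlorine, or a cyclohexyl ring, would match compound 1 at this place. As far as these compounds go, it is also open whether a longer chain between the amine nitrogen and the 3-chlorophenyl ring would strengthen or weaken inhibition.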